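Shortening the hydroxamate chain on the aminopyrazolopyrimidine benzoxazole

The compounds below may be only part of what the source reports. "The series", "measured", "known", "first", "only" and "open" are said of these compounds alone.

Measured compounds:
compound 1, `Nc1nc2cc(-c3nn(CCCCCCCCCC(=O)NO)c4ncnc(N)c34)ccc2o1`, 36800 nM
compound 2, `Nc1ncnc2c1c(-c1cnc3[nH]ccc3c1)nn2CCCCCCCCC(=O)NO`, 2270 nM
compound 3, `Nc1ncnc2c1c(-c1cnc3[nH]ccc3c1)nn2CC(=O)NO`, > 150000 nM

Of the compounds shown here, three sharing the aminopyrazolopyrimidine core have been tested in a functional assay on CNE-2 cells (Homo sapiens) for inhibition, read by MTT assay, with a stated time of 72 h; on this read-out lower numbers stand for stronger inhibition and higher numbers for weaker inhibition. Compound 1 gives 36800 nM in this assay, the highest of the two numbers that were read. Compound 2, which carries a different aromatic group on the core and a chain one carbon shorter, gives 2270 nM, a lower number that lies beyond the scatter. Compound 3 gives only a limit, > 150000 nM, and no number; this is the limit of > 150000 nM in this assay, at which 1 of the 3 values shown sits.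

The unmeasured compound 4, `Nc1nc2cc(-c3nn(CCCCCCC(=O)NO)c4ncnc(N)c34)ccc2o1`, keeps the core and the aromatic group of compound 1 and differs only in the chain: hydroxycarbamoyl in place of 3-(hydroxycarbamoyl)propyl on a saturated chain carbon, six bonds along the chain from an aromatic nitrogen. Among the measured compounds, the very short chain of compound 3 is the one that reaches the limit, while the long chains of compound 1 and compound 2 give numbers. Compound 4 sits between those chain lengths, so compound 4 is expected to give a number in this assay, though a step of a 1.6-fold higher number from compound 1 to compound 4 (0.21 log units; within the scatter) towards weaker inhibition is estimated, beyond the scatter. The estimate for compound 4 in this assay is 60000 nM, within 15000 nM to 150000 nM.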

Compound 4, half-maximal inhibitory concentration: 4360 nM
The estimate for compound 4 lay 14-fold (1.14 log units) above the measured number; measured number outside the range, below it.
By their numbers in this assay, from the lowest: compounds 2 and 4 (each within the scatter of the next); then compound 1. At a limit, above all of these: compound 3.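

In this assay, for the compounds shown here, the change from compound 1 to compound 4 gives the first reading of chain length with the core and the aromatic group both held fixed: an 8.4-fold lower number from compound 1 to compound 4 (0.93 log units; beyond the scatter). With hydroxycarbamoyl in place of 3-(hydroxycarbamoyl)propyl on a saturated chain carbon, six bonds along the chain from an aromatic nitrogen, the shorter chain goes with stronger inhibition, so on this aromatic group the longer chain of compound 1 is not the better one. With the other aromatic group, compound 3, which carries the much shorter (hydroxycarbamoyl)methyl chain, gives a limit and not a number: the limit of > 150000 nM in this assay, at which 1 of the 4 values shown sits.

On these data alone, compound 1 and compound 4 supply only these chain lengths on this aromatic group, so it remains open whether the number keeps falling with further shortening or rises again, as a (hydroxycarbamoyl)methyl chain on this aromatic group would show. Also open, as far as these compounds go, is what a carboxylic acid or a primary amide in place of hydroxycarbamoyl on compound 4 would give, and so whether the hydroxycarbamoyl group itself is needed for this level of inhibition.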